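The source may hold more compounds than are shown below. What is called first, only, known or untested is meant among the compounds shown, and "the series" means these compounds.

Measured compounds:
- compound 1, `COc1cc2c(Oc3ccc(NC(=O)C4(c5nnc(-c6ccc(F)cc6)o5)CC4)cc3F)ccnc2cc1OCCCN1CCCC1`: 2340 nM
- compound 2, `COc1cc2nccc(Oc3ccc(NC(=O)c4ncc(-c5ccc(F)cc5)o4)cc3)c2cc1OC`: 21900 nM
- compound 3, `COc1cc2c(Oc3ccc(NC(=O)c4nc(-c5ccc(F)cc5)no4)cc3)ccnc2cc1OCCCN1CCC(C)CC1`: 1040 nM

All three were run in a functional assay on PC-3 cells (Homo sapiens) for antiproliferative activity, read by MTT assay, with a stated time of 72 h; a higher number here means a weaker inhibitor, a lower number a stronger inhibitor. Among the three numbers compound 1 sits second highest: compound 3 gives the lower number, compound 2 the clearly higher one, and both gaps to compound 1 are beyond the usual scatter. The three compounds differ at several places at once, so none of these gaps can be tied to a single change.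

Compound 4, `COc1cc2c(Oc3ccc(NC(=O)C4(c5nnc(-c6ccc(F)cc6)o5)CC4)cc3F)ccnc2cc1OCCCN1CCN(C)CC1`, has not been measured. It differs from compound 1 in one place only: 4-methylpiperazin-1-yl in place of pyrrolidin-1-yl on a saturated chain carbon, three bonds along the chain from an oxygen on an aromatic ring. Among the measured compounds shown here, no measured pair in this set isolates a change of that kind, so there is no step in hand to calibrate on. In this assay compound 4 is expected to give a number close to that of compound 1, with a step of a 1.3-fold lower number from compound 1 to compound 4 (0.11 log units; within the scatter) that may well fall within the scatter and, if anything, leans toward a slightly lower number. The estimate for compound 4 in this assay is 1800 nM, with a range from 700 nM to 4500 nM.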

Compound 4, half-maximal inhibitory concentration: 1670 nM
Estimate against measurement, compound 4: 1.1-fold (0.03 log units) above, and the stated range covers the measured number.
By their numbers in this assay, from the lowest: compounds 3, 4 and 1 (each within the scatter of the next, the first and the last beyond it); then compound 2.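

In this assay, among the compounds shown here, the first step that differs in one place only gives a 1.4-fold lower number from compound 1 to compound 4 (0.15 log units; within the scatter). At this place, on a saturated chain carbon three bonds along the chain from an oxygen on an aromatic ring, 4-methylpiperazin-1-yl in place of pyrrolidin-1-yl therefore gives no readable difference, although the six-membered ring brings a second ring nitrogen and a methyl group. Nothing available bears on why the step is this small.

Still open, from the compounds shown here alone, is whether a morpholine, a primary amine or a carboxylic acid at the end of the chain, or a longer chain, would stay as close to compound 1. Also open, going by these compounds, is whether the same exchange would give a similar step on the core of compound 3.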